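Swapping an azide for an amine on compound 1

The compounds below may be only part of what the source reports. "The series", "measured", "known", "first", "only" and "open" are said of these compounds alone.

Compound 1, with the structure `[N-]=[N+]=Nc1nccc2c1ncn2[C@H]1C[C@H](O)[C@@H](CO)O1`, was tested in a functional assay on EL4 cells (Mus musculus) for inhibition, tested at 100 uM; a higher number here means more inhibition at the concentration tested (going by the name of the read-out), a lower number less inhibition. For the measured compounds named here, compound 1 gives 13%, the only plain number among the values seen so far. Compound 2, `OC[C@H]1O[C@@H](n2cnc3cnccc32)[C@H](O)[C@@H]1O`, reaches only the limit of the assay: in this assay compound 2 gives < 5%; < 5% (2 entries). Compound 3, `OCCNc1[nH]ccc2ncnc1-2`, likewise stays at the limit, giving < 5% in this assay. This limit is the floor (the limit of < 5% in this assay, at which 1 of the 3 values shown sits). Going by the values given here, no measured pair differs in a single place, so no step has a known size yet. Compound 4, `Nc1nccc2c1ncn2[C@H]1C[C@H](O)[C@@H](CO)O1`, differs from compound 1 as follows: amino in place of azido on an aromatic carbon. The step from compound 1 to compound 4 is expected to be small and downward, a number 5 percentage points lower from compound 1 to compound 4 (within the scatter). Compound 4 is expected to give about 8%, between 0% and 20%.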

Compound 4, a percentage reported as inhibition, at one concentration (the size of the read-out at that concentration, not a potency): 89%
Beside the measured number, compound 4's estimate is 81 percentage points below it; measured number outside the range, above it.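

Exchanging azido for amino on this aromatic carbon, next to the ring nitrogen, gives a number 76 percentage points higher from compound 1 to compound 4 (beyond the scatter) in this assay. For the compounds shown here, this is the first sign that inhibition depends strongly on the group at this one position, which no earlier pair could show. Nothing shown here explains why the amino group has this effect.

As far as these compounds go, it remains open whether a methylamino group or a hydroxyl group at this position would keep the inhibition. From the compounds shown here alone, it is also open whether the amino group would do the same on a core with a different sugar.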